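Chloro in Place of Fluoro: One Change, Two Positions

The source may report more compounds than this note shows. Statements on the series, on what has been measured and on what is new or still open speak of the compounds shown alone.

Compound 1 `O=C(CSc1nc(Nc2ccccc2)c2ccccc2n1)Nc1ccccc1F` and compound 2 `O=C(CSc1nc(Nc2ccccc2)c2ccccc2n1)Nc1ccccc1Cl` are compared in a functional assay on MDA-MB-231 cells (Homo sapiens) for inhibition, read by MTT assay, with a stated time of 72 h; a higher number here means a weaker inhibitor, a lower number a stronger inhibitor. Compound 1 reaches only > 50000 nM, which is a limit of the assay and not a number (the limit of > 50000 nM in this assay, at which 1 of the 3 values shown sits). Compound 2 gives 24400 nM. The change between the two is chloro in place of fluoro on an aromatic carbon, and it made a step of an at least 2.0-fold lower number from compound 1 to compound 2 (0.31 log units; beyond the scatter).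

Compound 3 `C=CC(=O)Nc1cccc(NC(=O)CSc2nc(Nc3ccc(F)cc3)c3ccccc3n2)c1` gives 9490 nM in this assay, the lowest number among the measured compounds. How the core of compound 3 differs from the core of compound 1 is not broken down here. Compound 4 `C=CC(=O)Nc1cccc(NC(=O)CSc2nc(Nc3ccc(Cl)cc3)c3ccccc3n2)c1` is not yet measured; it differs from compound 3 by chloro in place of fluoro on an aromatic carbon. This is the same kind of change as from compound 1 to compound 2, but not the same change, since in compound 2 the chloro sits ortho to a large group while in compound 4 it sits para to a large group. Resting on the measured step of an at least 2.0-fold lower number from compound 1 to compound 2 (0.31 log units; beyond the scatter), and set somewhat smaller since the place differs, the expected step is a 1.6-fold lower number from compound 3 to compound 4 (0.20 log units; within the scatter). Compound 4 is therefore estimated at 6000 nM, with a range from 2500 nM to 15000 nM.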

Compound 4, half-maximal inhibitory concentration: 10300 nM
Compound 4: the middle estimate sits 1.7-fold (0.23 log units) below what was measured; the measured number falls inside the stated range.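

In this assay, chloro in place of fluoro on the 4-fluorophenyl group gave a 1.1-fold higher number from compound 3 to compound 4 (0.04 log units; within the scatter), so on this core the two values cannot be told apart from repeated measurements of a single compound. Set beside the earlier step, the same change on the other core does not give a settled comparison: the same change on two cores in this assay, an at least 2.0-fold lower number (0.31 log units; beyond the scatter) from compound 1 to compound 2 and a 1.1-fold higher number (0.04 log units; within the scatter) from compound 3 to compound 4; the limit leaves it open whether they differ. This shows neither that the change carries from one core to the other nor that it fails to carry, and the value of compound 1 is a limit of the assay and not a number: the limit of > 50000 nM in this assay, at which 1 of the 4 values shown sits.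

Still open, going by these compounds, is whether a different group at the place para to a large group, such as an amine, a methoxy or a carboxylic acid, would separate itself from chloro and fluoro on the core of compound 3. Also open, on these data alone, is how large the step on the core of compound 1 really is, and whether it would stay the same with the chloro at another place on that ring.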